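A few compounds are considered here, and "the series" means these few. Any claim that something is new, unique, unknown or untested is made for them only; others in the source may bear on it.

Compound 1 `Cn1nccc1-c1cnc(NCc2c(F)ccc3c2CCO3)c2cn[nH]c(=O)c12` is the least soluble of the three measured compounds: in a physicochemical assay for solubility, read by LC-MS, in phosphate buffer, with a stated time of 24 h, at pH 7.4 (on this read-out lower numbers stand for lower solubility and higher numbers for higher solubility), compound 1 gives 2000 nM, whereas compound 2 `CC1(C)CC(=O)N(c2cnc(NCc3c(F)ccc4c3CCO4)n3cnnc23)C1` gives 57000 nM and compound 3 `CN(c1ccn(C)n1)c1cnc(NCc2c(F)ccc3c2CCO3)n2cnnc12` gives 130000 nM. Compound 4 `CNC(=O)c1ncc(-c2cnc(NCc3c(F)ccc4c3CCO4)c3cn[nH]c(=O)c23)n1C` differs from compound 1 by 1-methyl-2-(methylcarbamoyl)-1H-imidazol-5-yl in place of 1-methyl-1H-pyrazol-5-yl on an aromatic carbon. Among the measured compounds shown here, the only measured step, a 2.3-fold higher number from compound 2 to compound 3 (0.36 log units; beyond the scatter), concerns a different exchange on a different core, so it bears only loosely on this change, and no step touches the group that leaves here. Compound 1 is therefore the sole anchor. Because compound 1 sits at 2000 nM, compound 4 is expected to move modestly upward, by a 2.5-fold higher number from compound 1 to compound 4 (0.40 log units; beyond the scatter). Compound 4 is estimated at 5000 nM, within 1500 nM to 15000 nM.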

Compound 4, solubility: 5000 nM
Beside the measured number, compound 4's estimate shows no gap at the digits printed, within the range that was stated.
By their numbers in this assay, from the lowest: compound 1; then compound 4; then compound 2; then compound 3.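

On the shared core, 1-methyl-2-(methylcarbamoyl)-1H-imidazol-5-yl in place of 1-methyl-1H-pyrazol-5-yl on this aromatic carbon gives, in this assay, a 2.5-fold higher number from compound 1 to compound 4 (0.40 log units; beyond the scatter). Among the compounds shown here, this is the first measured step at this position, and it shows that the larger group, with its added hydrogen-bond donor, goes with a modest rise in the number. No evidence at hand accounts for this rise. The compounds shown leave open how much of the step belongs to the methylcarbamoyl part and how much to the exchange of the ring itself. They also leave open whether an amine or a carboxylic acid at this position would move the number further.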